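Compound 4 expected close to compound 3

This account rests on a few compounds, and the source may have more. Where it says the series, first, only, none or still open, it means among the compounds named here.

Three measured compounds share one core and differ only in the ring on the carbonyl carbon. In a functional assay on the whole organism (blood) with Rattus norvegicus as the target, with stated times of 24 h and 1 h, at a dose of 5 mg/kg by the intraperitoneal route (a lower number here means a weaker effect, a higher number a stronger effect of the compound at the dose given), compound 1 `COc1ccc(Cl)cc1C(=O)NCCC1CCN(S(=O)(=O)NC(=O)NC[C@@H]2C[C@@H]3C=C[C@@H]2C3)CC1` gives 37% and compound 2 `Cc1cccc(C(=O)NCCC2CCN(S(=O)(=O)NC(=O)NC[C@@H]3C[C@@H]4C=C[C@@H]3C4)CC2)n1` gives 20%. Compound 3 `COc1ccncc1C(=O)NCCC1CCN(S(=O)(=O)NC(=O)NC[C@@H]2C[C@@H]3C=C[C@@H]2C3)CC1` gives 14% in this assay, which sits below compound 1 beyond the scatter, while compound 2 lies within the scatter of it. Compound 4 `O=C(NC[C@@H]1C[C@@H]2C=C[C@@H]1C2)NS(=O)(=O)N1CCC(CCNC(=O)c2cc(Cl)ccn2)CC1` is not yet measured; it differs from compound 3 by 4-chloropyridin-2-yl in place of 4-methoxypyridin-3-yl on a carbonyl carbon. The steps of a number 17 percentage points lower from compound 1 to compound 2 (beyond the scatter) and a number 23 percentage points lower from compound 1 to compound 3 (beyond the scatter) show that changing this ring can matter, yet exchanging one such ring for another, a number 6 percentage points lower from compound 2 to compound 3 (within the scatter), stayed within the scatter. A step within the scatter is therefore expected, a number 4 percentage points higher from compound 3 to compound 4 (within the scatter). Compound 4 is estimated at 18%, between 5% and 38%.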

Compound 4, a percentage reported as activity, at one dose (the size of the read-out at that dose, not a potency): 32%
For compound 4 the middle estimate is 14 percentage points below the measured one; the measured number falls inside the stated range.
By their numbers in this assay, from the lowest: compounds 3 and 2 (each within the scatter of the next); then compounds 4 and 1 (each within the scatter of the next).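

In this assay, exchanging one pyridinyl ring on the carbonyl carbon for another can clearly matter: 4-chloropyridin-2-yl gives a number 18 percentage points higher from compound 3 to compound 4 (beyond the scatter) and a number 12 percentage points higher from compound 2 to compound 4 (beyond the scatter). A pyridinyl ring can also keep pace with 5-chloro-2-methoxyphenyl at this position, with a number 5 percentage points lower from compound 1 to compound 4 (within the scatter). Nothing available explains these differences.

The step to 4-chloropyridin-2-yl changes both the ring's substituent and its attachment point, and the compounds shown do not separate the two. A 4-methoxypyridin-2-yl group or a 4-chloropyridin-3-yl group would address this.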